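This account rests on a few compounds, and the source may have more. Where it says the series, first, only, none or still open, it means among the compounds named here.

Measured so far:
compound 1 `COc1cc(Br)cc(/C=C/C(=O)c2ccccc2)c1O`: 40.7%
compound 2 `COC(=O)C1=C(N)Oc2c(OC)cc(Br)cc2C1CC(=O)c1ccc(Cl)cc1`: 47.8%

In an ADME assay on MCF-10A cells (Homo sapiens) for cytotoxicity, read by sulforhodamine B assay, with a stated time of 72 h, tested at 30 uM (on this read-out higher numbers stand for a stronger effect at the one concentration tested and lower numbers for a weaker effect), compound 2 gives 47.8%, the higher of the two numbers recorded, and compound 1 gives 40.7%; the gap between them lies within the scatter, so the two cannot be ordered against each other. Going by the values given here, no pair of measured compounds differing in a single place is at hand, so no step from a known structural change can be drawn on here.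

Compound 3 `COc1cc(Br)cc2c1OC(N)=C(C#N)C2CC(=O)c1ccc(Cl)cc1` has not yet been run in this assay. Compared with compound 2 the change is cyano in place of methoxycarbonyl on a double-bonded ring carbon. With both measured compounds sitting close together and no comparable change recorded, no step beyond the scatter is expected for this exchange. The expected step is a number 2.8 percentage points lower from compound 2 to compound 3 (within the scatter). For compound 3 the estimated value in this assay is 45%, within a range from 28% to 62%.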

Compound 3, a percentage reported as activity, at one concentration (the size of the read-out at that concentration, not a potency): 41.6%
Compound 3: middle estimate off by 3.4 percentage points, on the high side; the measured number falls inside the stated range.
By their numbers in this assay, from the lowest: compounds 1, 3 and 2 (each within the scatter of the next).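

Going by these compounds alone, the first single-place step comes from the exchange of methoxycarbonyl for cyano on a double-bonded ring carbon, which in this assay gives a number 6.2 percentage points lower from compound 2 to compound 3 (within the scatter) and stays within the scatter. At this position, therefore, the read-out does not separate the two groups, even though cyano has fewer heavy atoms and fewer hydrogen-bond acceptors than methoxycarbonyl. No measured evidence bears on the size of this step.

As far as these compounds go, whether a carboxylic acid or a primary amide on this double-bonded ring carbon would give a step beyond the scatter remains open. Compound 1 differs from compound 2 and compound 3 in more than one place, so it offers no reading on this position.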